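A Bromo Added to an Inactive Compound

The compounds below may be only part of what the source reports. "The series", "measured", "known", "first", "only" and "open" are said of these compounds alone.

In a functional assay on HeLa cells (Homo sapiens) for cytotoxicity, read by MTT assay, with a stated time of 4 h (a lower number here means a stronger inhibitor, a higher number a weaker inhibitor), compound 3 `Cn1cc(/C=N\NC(=O)c2cn(C)c3ccccc23)c2ccccc21` gives "not active" (no number reported) as its result, so it stands without a single number. Compound 1 `Cn1cc(C(=O)N/N=C\c2c[nH]c3ccccc23)c2cc(Br)ccc21` likewise gives "not active" (no number reported) as its result, although it carries a bromo. Only compound 2 `COc1ccc2[nH]cc(/C=N\NC(=O)c3cn(C)c4ccc(Br)cc34)c2c1` yields a number, 14300 nM as its result, and it also carries a bromo. Compound 4 `Cn1cc(/C=N\NC(=O)c2cn(C)c3ccc(Br)cc23)c2ccccc21` differs from compound 3 by bromo in place of hydrogen on an aromatic carbon with bromo in place of hydrogen on an aromatic carbon. Among the measured compounds shown here, no measured step isolates this change. A step from no activity towards weak, measurable inhibition is expected, near compound 2 at 14300 nM in size, though compound 1 goes against this. For compound 4 the estimated value is 20000 nM within an expected range of 8000 nM to 60000 nM for now.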

Compound 4, half-maximal inhibitory concentration: 1690 nM
Compound 4: middle estimate off by 12-fold (1.07 log units), on the high side; measured number outside the range, below it.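

Among the compounds shown here, compound 3 has no single number, and no step to compound 4 can be read from it. The compounds shown leave open how much of the activity of compound 4 goes with the bromo. No evidence bearing on this result is available.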